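This account rests on a few compounds, and the source may have more. Where it says the series, first, only, none or still open, it means among the compounds named here.

In an ADME assay on MT4 cells (Homo sapiens) for cytotoxicity, read by MTT assay, with a stated time of 96 h (a lower number here means that less compound is tolerated, a higher number that more compound is tolerated), compound 1 `Cc1ccccc1C1CC(c2ccc(OCc3ccccc3)cc2)=NN1c1ccc(S(N)(=O)=O)cc1` gives >= 100000 nM, which is a limit and not a number. Compound 2 `NS(=O)(=O)c1ccc(N2N=C(c3ccc(OCc4ccccc4)cc3)CC2c2ccccc2)cc1` also gives only a limit, > 100000 nM. For the measured compounds named here, compound 3 `NS(=O)(=O)c1ccc(N2N=C(c3ccc(OCc4ccccc4)cc3)CC2c2cccc(Cl)c2)cc1` gives the only true number so far, 36000 nM.

The two limits leave a step that the two limits leave unreadable from compound 1 to compound 2. The other measured steps are an at least 2.7-fold lower number from compound 2 to compound 3 (0.44 log units; beyond the scatter) and an at least 2.7-fold lower number from compound 1 to compound 3 (0.44 log units; beyond the scatter), both beyond the scatter. All three steps change only the aryl group on the saturated ring carbon, and compound 4 `Cc1ccccc1C1CC(c2ccccc2)=NN1c1ccc(S(N)(=O)=O)cc1` keeps that group as in compound 1.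

The change here lies elsewhere: hydrogen in place of benzyloxy on an aromatic carbon, para to a large group. Going by the values given here, no measured step touches this place, so the evidence bears on it only weakly.

The expectation therefore starts from compound 1 at its limit of >= 100000 nM. The expected step is an at least 1.1-fold lower number from compound 1 to compound 4 (0.04 log units; that floor lies within the scatter), and no shift beyond the scatter is expected in either direction. For compound 4 the estimate is 90000 nM, with an expected range of 35000 nM to 200000 nM.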

Compound 4, half-maximal cytotoxic concentration: 43000 nM
The estimate for compound 4 lay 2.1-fold (0.32 log units) above the measured number, within the range that was stated.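

In this assay, for the compounds shown here, hydrogen in place of benzyloxy on an aromatic carbon, para to a large group, gives an at least 2.3-fold lower number from compound 1 to compound 4 (0.36 log units; beyond the scatter), the first reading at this place. The benzyloxy group is therefore not required for a measurable cytotoxic concentration, and this place joins the aryl group on the saturated ring carbon as a second site where a change moves the reading beyond the scatter. The step gives only a floor for the true size of the change because compound 1 stands at a limit: the limit of >= 100000 nM in this assay, at which 1 of the 4 values shown sits.

Hydrogen and benzyloxy are the only groups shown at this place, so it remains open where a methoxy group, an amine or a carboxylic acid there would fall. Going by these compounds, it is also open whether the same change would give a similar step with the unsubstituted phenyl of compound 2 or the 3-chlorophenyl of compound 3 on the saturated ring carbon.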